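The source may hold more compounds than are shown below. What is called first, only, known or untested is meant among the compounds shown, and "the series" means these compounds.

Working notes on the series. Compound 1, `COc1cc(-c2nn(-c3cccc(NC(=O)c4ccc(Cl)c(C(F)(F)F)c4)c3)cc2-c2ccncc2)ccc1Cl`, is the reference point here. In a functional assay on MDA-MB-231 cells (Homo sapiens) for inhibition, read by sulforhodamine B assay, with a stated time of 48 h (on this read-out lower numbers stand for higher toxicity in this test and higher numbers for lower toxicity in this test), compound 1 gives > 32500 nM, which is a limit of the assay and not a number. Compound 2, `O=C(Nc1cccc(-n2cc(-c3ccncc3)c(-c3ccc(Cl)c(O)c3)n2)c1)Nc1cc(C(F)(F)F)cc(C(F)(F)F)c1`, belongs to the same set; in this assay compound 2 gives 3720 nM. For the measured compounds named here, no two of the measured compounds differ in a single place, so no measured step exists, and all that can be said of where compound 1 stands is the limit of > 32500 nM in this assay, at which 1 of the 2 values shown sits. Compound 3, `COc1cc(-c2nn(-c3cccc(NC(=O)Nc4cccc(C(F)(F)F)c4)c3)cc2-c2ccncc2)ccc1Cl`, is the next compound to be run in this assay. It differs from compound 1 by (3-(trifluoromethyl)phenyl)amino in place of 4-chloro-3-(trifluoromethyl)phenyl on a carbonyl carbon. The expected step of an at least 2.1-fold lower number from compound 1 to compound 3 (0.33 log units; beyond the scatter) is a modest move toward higher toxicity, though a result again at the limit remains quite possible. For compound 3 the estimated value in this assay is 15000 nM, with a range from 4000 nM to 40000 nM.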

Compound 3, concentration lethal to 50% of the cells: 25500 nM
Compound 3: middle estimate off by 1.7-fold (0.23 log units), on the low side, and the stated range covers the measured number.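

In this assay, (3-(trifluoromethyl)phenyl)amino in place of 4-chloro-3-(trifluoromethyl)phenyl on a carbonyl carbon gives an at least 1.2-fold lower number from compound 1 to compound 3 (0.10 log units; that floor lies within the scatter). Compound 3 gives 25500 nM, a number and not a limit, so this place can carry the change and still yield a reading in this assay. The step can be read only as a floor, and its true size stays unknown, because compound 1 stands at a limit of the assay: the limit of > 32500 nM in this assay, at which 1 of the 3 values shown sits.

The change brings in a nitrogen with its hydrogen and removes a chlorine in one move, and the compounds shown do not separate these two parts. Also open, as far as these compounds go, is how a dimethylamino group or a morpholine on the same carbonyl carbon would read.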